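This account rests on a few compounds, and the source may have more. Where it says the series, first, only, none or still open, it means among the compounds named here.

Measured in a functional assay on A549 cells (Homo sapiens) for cytotoxicity, read by WST assay, with a stated time of 24 h; on this read-out higher numbers stand for weaker inhibition and lower numbers for stronger inhibition:
compound 1 `COc1ccc2c(/C=C(\C#N)C(=O)c3c[nH]c4cc(F)ccc34)c[nH]c2c1`: 10300 nM
compound 2 `COc1ccc2c(/C=C(\C#N)C(=O)c3c[nH]c4cc(OC)ccc34)c[nH]c2c1`: 1900 nM
compound 3 `COc1ccc2[nH]cc(/C=C(\C#N)C(=O)c3c[nH]c4ccc(OC)cc34)c2c1`: > 50000 nM, a limit of the assay

Compound 2 has the lowest number of the three, and the next number belongs to compound 1. Compound 4 `COc1ccc2c(C(=O)/C(C#N)=C/c3c[nH]c4ccccc34)c[nH]c2c1` departs from compound 2 by hydrogen in place of methoxy on an aromatic carbon, with hydrogen in place of methoxy on an aromatic carbon. For the measured compounds named here, only one measured step bears on this, and it too brings a methoxy onto an aromatic carbon, though at a different carbon: a 5.4-fold lower number from compound 1 to compound 2 (0.73 log units; beyond the scatter). Losing a methoxy is therefore expected to raise the number modestly, by a step of similar size, though with little certainty. The expected step is a 3.2-fold higher number from compound 2 to compound 4 (0.50 log units; beyond the scatter). For compound 4 the estimated value is 6000 nM, with an expected range from 1800 nM to 25000 nM.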

Compound 4, half-maximal inhibitory concentration: 6400 nM
Compound 4: middle estimate off by 1.1-fold (0.03 log units), on the low side; measured number inside the range.
By their numbers in this assay, from the lowest: compound 2; then compounds 4 and 1 (each within the scatter of the next). At a limit, above all of these: compound 3.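

Hydrogen in place of methoxy on this carbon, meta to a fused ring and para to a fused ring, gives a 3.4-fold higher number from compound 2 to compound 4 (0.53 log units; beyond the scatter) and so shows that the methoxy here matters to the read-out. The earlier step, a 5.4-fold lower number from compound 1 to compound 2 (0.73 log units; beyond the scatter), concerned fluoro and methoxy on a different carbon, leaving this one untested. No measurement shown bears on why the number moves.

The compounds shown leave open how an amine, a hydroxyl or a longer chain such as ethoxy on this carbon would compare with compound 2.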